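Extending the chain beside the phenyl on compound 3

The source may report more compounds than this note shows. Statements on the series, on what has been measured and on what is new or still open speak of the compounds shown alone.

Three compounds share a core and were tested in an assay on Prostate gland for inhibition of steroid 5-alpha-reductase (Rattus norvegicus); on this read-out higher numbers stand for weaker inhibition and lower numbers for stronger inhibition. Compound 1 `CCCn1ccc2cc(/C(C)=C/C(=O)Nc3ccccc3OCCCC(=O)O)ccc21` gives 190 nM. Compound 2 `C/C(=C\C(=O)Nc1ccccc1OCCCC(=O)O)c1ccc2c(ccn2CC(C)C)c1` gives 160 nM. Compound 3 `CCCC(c1ccccc1)n1ccc2cc(/C(C)=C/C(=O)Nc3ccccc3OCCCC(=O)O)ccc21` gives 9.1 nM, the lowest of the three. The change from compound 1 to compound 2 is methyl in place of hydrogen on a saturated chain carbon bound to two saturated chain carbons, and it made a step of a 1.2-fold lower number from compound 1 to compound 2 (0.07 log units; within the scatter). The larger change from compound 1 to compound 3 is 1-phenylbutyl in place of propyl on an aromatic nitrogen, with a step of a 21-fold lower number from compound 1 to compound 3 (1.32 log units; beyond the scatter); the step of an 18-fold lower number from compound 2 to compound 3 (1.25 log units; beyond the scatter) is of similar size.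

Compound 4 `CCCCC(c1ccccc1)n1ccc2cc(/C(C)=C/C(=O)Nc3ccccc3OCCCC(=O)O)ccc21` is not yet measured. It differs from compound 3 by methyl in place of hydrogen on a saturated chain carbon, four bonds along the chain from an aromatic carbon and an aromatic nitrogen. This is the same kind of change as that from compound 1 to compound 2, though it sits at a different place: there the carbon is bound to two saturated chain carbons, here it lies four bonds along the chain from an aromatic carbon and an aromatic nitrogen. Because a 1.2-fold lower number from compound 1 to compound 2 (0.07 log units; within the scatter) stayed within the scatter, a similarly small step of a 1.1-fold lower number from compound 3 to compound 4 (0.06 log units; within the scatter) is expected for compound 4. Compound 4 is therefore estimated at 8 nM, between 3 nM and 20 nM.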

Compound 4, half-maximal inhibitory concentration: 9.8 nM
The estimate for compound 4 lay 1.2-fold (0.09 log units) below the measured number; the measured number falls inside the stated range.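

Adding this methyl to the chain of compound 3 gave a 1.1-fold higher number from compound 3 to compound 4 (0.03 log units; within the scatter), so the step lies within the scatter, while the 1-phenylpentyl group on compound 4 still shows a large difference from the shorter chains without a phenyl: a 16-fold lower number from compound 2 to compound 4 (1.21 log units; beyond the scatter) and a 19-fold lower number from compound 1 to compound 4 (1.29 log units; beyond the scatter). Carried from one core to another, the methyl change gave a small step both times, and the two steps do not differ: the same change on two cores in this assay, a 1.2-fold lower number (0.07 log units; within the scatter) from compound 1 to compound 2 and a 1.1-fold higher number (0.03 log units; within the scatter) from compound 3 to compound 4, 1.3-fold (0.11 log units) apart, within the scatter of two such steps. For the compounds shown here, that is only two pairs of compounds in one assay, with the methyl at a different place in each, so it does not show that this change would stay small at other places on the chain or on other cores.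

The compounds shown leave open how far the chain on the phenyl-bearing carbon can grow before the number moves, for example with a longer chain such as hexyl. They also leave open what an amine or a hydroxyl at the end of that chain would do.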